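Amine substituent changes on the shared core: working notes

The source may report more compounds than this note shows. Statements on the series, on what has been measured and on what is new or still open speak of the compounds shown alone.

In a functional assay on A-375 cells (Homo sapiens) for antiproliferative activity, read by CCK-8 assay, with a stated time of 72 h, tested at 8 uM (a lower number here means a weaker effect, a higher number a stronger effect of the compound at the concentration tested), the three measured compounds stand as follows:
compound 1 `Nc1ccccc1NC(=O)c1ccc(CSC(=S)N2CCN(C3CCCCC3)CC2)cc1`: 89.9%
compound 2 `CN(Cc1cccnc1)C(=S)SCc1ccc(C(=O)Nc2ccccc2N)cc1`: 83.8%
compound 3 `Nc1ccccc1NC(=O)c1ccc(CSC(=S)N2CCN(c3cnccn3)CC2)cc1`: 85.8%

Compound 3 holds the second highest of the three numbers; compound 2 is the nearest, within the scatter, and compound 1 the furthest, also within the scatter. Compound 4 `CN1CCN(C(=S)SCc2ccc(C(=O)Nc3ccccc3N)cc2)CC1` differs from compound 3 by methyl in place of pyrazin-2-yl on an amine nitrogen in a ring. Among the measured compounds shown here, the one step at the same position, a number 4.1 percentage points lower from compound 1 to compound 3 (within the scatter), stayed within the scatter, and compound 2, which also carries a methyl on an amine nitrogen, sits within the scatter of compound 3. No step beyond the scatter is therefore expected; the estimated change is a number 1.8 percentage points lower from compound 3 to compound 4 (within the scatter). Compound 4 is expected to give 84%, in the range 70% to 95%.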

Compound 4, a percentage reported as inhibition, at one concentration (the size of the read-out at that concentration, not a potency): 91.6%
Beside the measured number, compound 4's estimate is 7.6 percentage points below it, and the stated range covers the measured number.
By their numbers in this assay, from the lowest: compounds 2, 3, 1 and 4 (each within the scatter of the next).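

At this position on the ring amine nitrogen, this assay shows that the read-out holds when a single methyl replaces a far larger ring substituent: a number 5.8 percentage points higher from compound 3 to compound 4 (within the scatter), and a number 1.7 percentage points higher from compound 1 to compound 4 (within the scatter). Exchanging the whole amine on the thiocarbonyl carbon also stays within the scatter, with a number 7.8 percentage points higher from compound 2 to compound 4 (within the scatter). No measurement here offers an explanation for these steps.

From the compounds shown here alone, whether a carboxylic acid or a longer chain ending in a primary amine on this nitrogen would hold the read-out remains open. With one concentration only, potency differences among these compounds also remain open.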